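Solubility notes: compound 1 and its pyrrolidinylmethyl analogue

This account rests on a few compounds, and the source may have more. Where it says the series, first, only, none or still open, it means among the compounds named here.

Three compounds of the shared core have numbers in a physicochemical assay for solubility, read by HPLC, using the shake flask method, measured as kinetic solubility, with a stated time of 2 h, at pH 7.4; a higher number here means a more soluble compound, a lower number a less soluble compound. Compound 1 `Cc1cc(NCc2cnccn2)n2nc(C)c(-c3ccccc3)c2n1` gives 7100 nM. Compound 3 `Cc1cc(NCc2ccccn2)n2ncc(-c3ccc(C(=O)Nc4ccccc4)cc3)c2n1` gives 5000 nM, and these two values lie within the scatter of each other. Compound 2 `Cc1cc(NCc2ccccn2)n2ncc(-c3ccn(C)n3)c2n1` gives 188000 nM, a higher number than compound 1 by a gap beyond the scatter, so compound 1 stands second of the three. Compound 4 `CCN1CCCC1CNc1cc(C)nc2c(-c3ccccc3)c(C)nn12` is not yet measured; it differs from compound 1 in one place: 1-ethylpyrrolidin-2-yl in place of pyrazin-2-yl on a saturated chain carbon bound to a nitrogen on an aromatic ring. Among the measured compounds shown here, no measured pair shows this change, so its size is open. The step expected in this assay, a 4.9-fold higher number from compound 1 to compound 4 (0.69 log units; beyond the scatter), is upward and beyond the scatter. Compound 4 is estimated at 35000 nM, within 9000 nM to 130000 nM.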

Compound 4, solubility: 172000 nM
Beside the measured number, compound 4's estimate is 4.9-fold (0.69 log units) below it; the whole stated range lies below it.
By their numbers in this assay, from the lowest: compounds 3 and 1 (each within the scatter of the next); then compounds 4 and 2 (each within the scatter of the next).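

In this assay, replacing (pyrazin-2-yl)methyl with (1-ethylpyrrolidin-2-yl)methyl on the core of compound 1 gives a 24-fold higher number from compound 1 to compound 4 (1.38 log units; beyond the scatter), the first step read at this position. The large step shows that this position can strongly shift the read-out when a six-membered aromatic ring gives way to a five-membered non-aromatic ring. Nothing available explains the step.

Going by these compounds, whether it follows from the ring or from its ethyl group remains open. A 1-methylpyrrolidin-2-yl or a piperidin-2-yl group at this place would help separate those parts.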